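Chalcone working notes: a swap on the benzyloxy series

The source may hold more compounds than are shown below. What is called first, only, known or untested is meant among the compounds shown, and "the series" means these compounds.

Measured in a functional assay on HCT-116 cells (Homo sapiens) for inhibition, read by sulforhodamine B assay, with a stated time of 3 days; on this read-out higher numbers stand for weaker inhibition of growth and lower numbers for stronger inhibition of growth:
- compound 1 `O=C(/C=C/c1ccccc1Cl)c1ccc(OCc2ccccc2)cc1`: 14900 nM
- compound 2 `O=C(/C=C/c1cccc([N+](=O)[O-])c1)c1ccccc1`: 4470 nM
- compound 3 `O=C(/C=C/c1ccc(Cl)cc1)c1ccccc1`: 16500 nM

In this assay compound 1 gives 14900 nM. That lies within the scatter of compound 3 at 16500 nM, so the two cannot be ordered. Compound 2 at 4470 nM gives a lower number than compound 1, and that gap is beyond the scatter.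

Next in the series is compound 4 `COc1ccc(/C=C/C(=O)c2ccc(OCc3ccccc3)cc2)cc1`, not yet measured. It keeps the core of compound 1 and carries 4-methoxyphenyl in place of 2-chlorophenyl on a double-bonded chain carbon bound to a double-bonded chain carbon.

Among the measured compounds shown here, no two measured compounds differ in one place, so no measured step bears directly on this change. The expectation therefore rests only on the narrow spread of the set, whose lowest number comes from compound 2 at 4470 nM. The estimated step is a 1.7-fold lower number from compound 1 to compound 4 (0.22 log units; within the scatter), expected in this assay to run toward a lower number and not clearly beyond the scatter. For compound 4 the estimated value is 9000 nM, with an expected range of 3500 nM to 22000 nM.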

Compound 4, concentration for 50% growth inhibition: 36900 nM
Estimate against measurement, compound 4: 4.1-fold (0.61 log units) below, outside the stated range (above it).
By their numbers in this assay, from the lowest: compound 2; then compounds 1 and 3 (each within the scatter of the next); then compound 4.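

The swap to 4-methoxyphenyl in place of 2-chlorophenyl on a double-bonded chain carbon bound to a double-bonded chain carbon gives, in this assay, a 2.5-fold higher number from compound 1 to compound 4 (0.39 log units; beyond the scatter), a modest change but the first one-place step the series can read. It shows that this place on the core of compound 1 is not indifferent to the group it carries, and that this particular change goes toward weaker inhibition of growth. The change removes a chlorine and brings in an oxygen with one hydrogen-bond acceptor, yet a single step cannot separate these differences, and no supporting data explain the shift.

Open, as far as these compounds go, is how 2-methoxyphenyl, or a phenyl ring carrying an amine or a carboxylic acid, would stand on the same core, which would help separate the identity of the group from the place it occupies on the ring. Also open, from the compounds shown here alone, is whether the step carries over to the simpler compounds, since compound 2 and compound 3 differ from compound 1 and compound 4 in more than one place and offer no one-place comparison.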